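Replacing phenoxymethyl in compound 3

The source may hold more compounds than are shown below. What is called first, only, known or untested is meant among the compounds shown, and "the series" means these compounds.

Compound 1 `O=C(Cn1cc(F)c(=O)n(CC(=O)Nc2ccc(Br)cn2)c1=O)Nc1ccc(Br)cn1`: 11100 nM
Compound 2 `Cc1ccc(SCC(=O)Nc2ccc3nc(NC(=O)c4ccc(C(F)(F)F)cc4)sc3c2)c(C)c1`: 320 nM
Compound 3 `O=C(CSc1nnc(NC(=O)COc2ccccc2)s1)Nc1ccc(Br)cc1`: > 100000 nM (a limit, not a number)

In a functional assay on HCT-116 cells (Homo sapiens) for antiproliferative activity, read by MTT assay, with a stated time of 72 h (a lower number here means a stronger inhibitor, a higher number a weaker inhibitor), compound 2 gives 320 nM and compound 1 gives 11100 nM, so both have measured numbers. On these data alone, compound 3 has only a limit, > 100000 nM, and so its exact position on the scale is unknown.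

Compound 4 `COc1ccc(C(=O)Nc2nnc(SCC(=O)Nc3ccc(Br)cc3)s2)cc1OC` has not been measured yet. It keeps the core of compound 3 but carries 3,4-dimethoxyphenyl in place of phenoxymethyl on a carbonyl carbon. Among the measured compounds shown here, no two measured compounds differ in only one place, so no measured step in this assay shows how large this change might be. The expectation therefore rests mainly on compound 3, whose > 100000 nM is a limit. A modest gain in strength is expected, an at least 2.8-fold lower number from compound 3 to compound 4 (0.45 log units; beyond the scatter), although the result could also remain at the limit. Compound 4 is estimated at 35000 nM, with an expected range of 6000 nM to 100000 nM.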

Compound 4, half-maximal inhibitory concentration: 66600 nM
Beside the measured number, compound 4's estimate is 1.9-fold (0.28 log units) below it; low and high end bracket the measured number.
By their numbers in this assay, from the lowest: compound 2; then compound 1; then compound 4. At a limit, above all of these: compound 3.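

Among the compounds shown here, this is the first measured step at this position, on a carbonyl carbon whose other neighbour is an amide-type nitrogen. In this assay, for the compounds shown here, 3,4-dimethoxyphenyl in place of phenoxymethyl gives an at least 1.5-fold lower number from compound 3 to compound 4 (0.17 log units; that floor lies within the scatter), and compound 4 provides the first real number for this core. The true size of the step cannot be read, and it could be small or much larger, because compound 3 stands only at a limit: the limit of > 100000 nM in this assay, at which 1 of the 4 values shown sits.

On these data alone, what a plain phenyl group on this carbonyl carbon would give stays open, and with it whether the two methoxy groups or the loss of the phenoxymethyl chain accounts for any of the change. Also open, as far as these compounds go, is how an amine or a carboxylic acid on that ring would shift the number.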